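This account rests on a few compounds, and the source may have more. Where it says the series, first, only, none or still open, it means among the compounds named here.

Measured compounds and their values:
- compound 1 `Cc1ccc(C2=NN(C3=NC(c4ccccc4)CS3)C(c3ccc4ccccc4c3)C2)cc1C`: 950 nM
- compound 2 `Cc1ccc(C2=NN(C3=NC(c4ccccc4)CS3)C(c3cccc4ccccc34)C2)cc1C`: 1720 nM
- compound 3 `Cc1ccc(C2=NN(C3=NC(=O)CS3)C(c3ccc4ccccc4c3)C2)cc1C`: 860 nM

All three numbers come from a functional assay on HeLa cells (Homo sapiens) for inhibition, read by CCK-8 assay, with a stated time of 48 h; on this read-out higher numbers stand for weaker inhibition and lower numbers for stronger inhibition. Compound 1 stands second highest of the three. Its nearest neighbour is compound 3, reached by a 1.1-fold lower number from compound 1 to compound 3 (0.04 log units; within the scatter); its furthest is compound 2, reached by a 1.8-fold higher number from compound 1 to compound 2 (0.26 log units; within the scatter). Both steps stay within the scatter, so the three compounds cannot be ordered against each other on these numbers.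

Compound 4 `COc1ccc(C2=NN(C3=NC(c4ccccc4)CS3)C(c3ccc4ccccc4c3)C2)cc1` is not yet measured. It differs from compound 1 in one place: 4-methoxyphenyl in place of 3,4-dimethylphenyl on a carbon with a double bond to nitrogen.

Neither measured step bears on this change. The step from compound 1 to compound 2 varies the naphthyl attachment on a saturated ring carbon, and the step from compound 1 to compound 3 varies the group on the amine nitrogen in the ring; the aryl group on the carbon with a double bond to nitrogen is held constant in every measured compound. There is therefore no measured guide for this assay here, and with both known variations of the shared core staying within the scatter, no step beyond the scatter is expected in either direction.

Compound 4 is estimated at 1000 nM in this assay, with a range of 400 nM to 2500 nM. That estimate means an expected step of a 1.1-fold higher number from compound 1 to compound 4 (0.02 log units; within the scatter).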

Compound 4, half-maximal inhibitory concentration: 1860 nM
Compound 4: the middle estimate sits 1.9-fold (0.27 log units) below what was measured; measured number inside the range.
By their numbers in this assay, from the lowest: compounds 3, 1, 2 and 4 (each within the scatter of the next, the first and the last beyond it).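

Within the data shown here, this is the first variation of the aryl group on the carbon with a double bond to nitrogen, a place held constant in compounds 1, 2 and 3. In this assay, placing 4-methoxyphenyl there instead of 3,4-dimethylphenyl gives a 2.0-fold higher number from compound 1 to compound 4 (0.29 log units; within the scatter), so this single exchange does not separate the two compounds on these numbers. Among these compounds, the exchange replaces a carbon with an oxygen and adds 1 hydrogen-bond acceptor, yet no evidence on these compounds bears on what sets the size of this step.

One exchange of this kind leaves the range of this place unmapped: an unsubstituted phenyl, a 4-chlorophenyl, a 4-aminophenyl or a phenyl carrying a carboxylic acid could each show whether any group here gives a step beyond the scatter. Also open, going by these compounds, is whether 4-methoxyphenyl gives a comparable step when paired with the naphthalen-1-yl group of compound 2, or with the group on the ring nitrogen of compound 3.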